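The source may report more compounds than this note shows. Statements on the series, on what has been measured and on what is new or still open speak of the compounds shown alone.

Going by the values given here, compound 1 `Clc1cccc2c1C=C(CC1CN=CN1)CC2` is the stronger-looking of the two compounds measured so far in an assay on isolated protein for binding affinity to Adrenergic receptor alpha-1 (Rattus norvegicus), read by radioligand binding, in the presence of a further agent that is not named here (on this read-out higher numbers stand for weaker inhibition and lower numbers for stronger inhibition), where compound 1 gives 398 nM. Among the compounds with values here, its only measured neighbour, compound 2 `Fc1cccc2c1C=C(CC1CN=CN1)CC2`, differs by a fluoro in place of the chloro on an aromatic carbon and gives 501 nM in this assay; the step of a 1.3-fold higher number from compound 1 to compound 2 (0.10 log units; within the scatter) is within the scatter, so the two values cannot be told apart.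

Compound 3 `NC1=NCC(CC2=Cc3c(Cl)cccc3CC2)O1` keeps the chloro-bearing core of compound 1 and changes the ring hanging from the saturated chain carbon: a group of 6 heavy atoms (3 carbon, 2 nitrogen, 1 oxygen; one five-membered non-aromatic ring with 2 hetero atoms) in place of a group of 5 heavy atoms (3 carbon, 2 nitrogen; one five-membered non-aromatic ring with 2 hetero atoms), on a saturated chain carbon bound to a double-bonded ring carbon. Within the data shown here, no measured step touches this part of the molecule; the single step known, from compound 1 to compound 2, concerns only the halogen on the aromatic ring and says nothing about the five-membered ring. The expectation for compound 3 therefore rests on the change itself, and the guess is a modestly weaker binding, a step of a 2.5-fold higher number from compound 1 to compound 3 (0.40 log units; beyond the scatter) in this assay. Compound 3 is thus estimated at 1000 nM, with a range from 200 nM to 5000 nM.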

Compound 3, inhibition constant: 316 nM
Compound 3: middle estimate off by 3.2-fold (0.50 log units), on the high side, and the stated range covers the measured number.
By their numbers in this assay, from the lowest: compounds 3, 1 and 2 (each within the scatter of the next).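

At the saturated chain carbon bound to a double-bonded ring carbon, the group of 6 heavy atoms (3 carbon, 2 nitrogen, 1 oxygen) can take the place of the group of 5 heavy atoms (3 carbon, 2 nitrogen) without a readable difference in this assay (a 1.3-fold lower number from compound 1 to compound 3 (0.10 log units; within the scatter)). Going by these compounds alone, this is the first measured change at this position, and it shows that a ring oxygen and 3 hydrogen-bond acceptors in place of 2 can be present here while the reading stays within the scatter. Nothing available here explains this result.

The compounds shown leave open whether the same exchange would give a similar reading on the fluoro-bearing core of compound 2. They also leave open how an amine or a carboxylic acid would read on this same chain carbon.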